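Notes on a para substituent swap in the benzylsulfanyl series

This account rests on a few compounds, and the source may have more. Where it says the series, first, only, none or still open, it means among the compounds named here.

Among the compounds with values here, compound 1 `Cc1cc(Nc2cc(-c3ccccc3)[nH]n2)n2nc(SCc3ccc(Cl)cc3)nc2n1` and compound 2 `Cc1cc(Nc2ccn(Cc3ccc(C(F)(F)F)cc3)n2)n2nc(SCc3ccc(Br)cc3)nc2n1` are the only members measured so far in a functional assay on MGC-803 cells (Homo sapiens) for inhibition, read by MTT assay, with a stated time of 72 h; a higher number here means a weaker inhibitor, a lower number a stronger inhibitor. Compound 1 gives 3950 nM and compound 2 gives 2590 nM; compound 1 has the higher of the pair, but the gap to compound 2 lies within the scatter, so no order between them can be read. Within the data shown here, no pair of measured compounds differs in a single place, so the series carries no step of known size yet.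

Compound 3 `COc1ccc(CSc2nc3nc(C)cc(Nc4cc(-c5ccccc5)[nH]n4)n3n2)cc1` is not yet measured in this assay. It differs from compound 1 in one place: methoxy in place of chloro on an aromatic carbon. Nothing measured here bears directly on this change, so the expectation rests on the value of compound 1 alone. The step of a 1.1-fold higher number from compound 1 to compound 3 (0.06 log units; within the scatter) is expected to be small, in either direction, and not beyond the scatter. Compound 3 is expected to give 4500 nM in this assay, within a range of 1500 nM to 13000 nM.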

Compound 3, half-maximal inhibitory concentration: 3170 nM
The estimate for compound 3 lay 1.4-fold (0.15 log units) above the measured number, within the range that was stated.
By their numbers in this assay, from the lowest: compounds 2, 3 and 1 (each within the scatter of the next).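

The exchange of (4-chlorobenzyl)sulfanyl for (4-methoxybenzyl)sulfanyl gives the series its first step of known size: in this assay, a 1.2-fold lower number from compound 1 to compound 3 (0.10 log units; within the scatter). On this aromatic carbon, para to a large group, chloro and methoxy therefore cannot be told apart in this assay, even though methoxy carries a hydrogen-bond acceptor that chloro lacks and the two differ in heavy atoms. No supporting measurement bears on this result, so it stands as an observation only.

On these data alone, whether an amine, a carboxylic acid or a longer alkoxy chain at this position would give a step beyond the scatter remains open. Compound 2 differs from compound 1 and compound 3 in more than one place, so it also leaves open how the bromo group compares here and whether the step from chloro to methoxy would hold on another amino substituent.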